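This account rests on a few compounds, and the source may have more. Where it says the series, first, only, none or still open, it means among the compounds named here.

Measured in a functional assay on HCT-15 cells (Homo sapiens) for inhibition, read by MTT assay, with a stated time of 72 h; a lower number here means a stronger inhibitor, a higher number a weaker inhibitor:
- compound 1 `COc1ccc(CCCNCc2c(OC)cc(Oc3ccc(Nc4ccccc4)cc3)cc2OC)cc1`: 2180 nM
- compound 2 `COc1cc(Oc2cccc(Nc3ccccc3)c2)cc(OC)c1CNCc1ccc(C)cc1`: 5400 nM
- compound 3 `COc1ccc([C@@H](C)NCc2c(OC)cc(Oc3cccc(Nc4ccccc4)c3)c(OC)c2OC)cc1`: 4690 nM

Compound 2 at 5400 nM cannot be told apart from compound 3 at 4690 nM because the two lie within the usual scatter. Compound 2 is a weaker inhibitor than compound 1, and that gap lies beyond the scatter.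

Compound 4 `COc1cc(Oc2cccc(Nc3ccccc3)c2)cc(OC)c1CCO` has hydroxymethyl in place of (4-methylbenzyl)amino on a saturated chain carbon bound to an aromatic carbon. For the measured compounds named here, no measured pair shows this change, and all three measured compounds carry an amino group on that chain. A moderate move towards a higher number is therefore expected, an estimated 1.9-fold higher number from compound 2 to compound 4 (0.27 log units; within the scatter). For compound 4 the estimated value is 10000 nM, within an expected range of 3500 nM to 30000 nM.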

Compound 4, half-maximal inhibitory concentration: 12100 nM
Beside the measured number, compound 4's estimate is 1.2-fold (0.08 log units) below it, and the stated range covers the measured number.
By their numbers in this assay, from the lowest: compound 1; then compounds 3 and 2 (each within the scatter of the next); then compound 4.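

In this assay, for the compounds shown here, replacing (4-methylbenzyl)amino with hydroxymethyl on a saturated chain carbon bound to an aromatic carbon gives a 2.2-fold higher number from compound 2 to compound 4 (0.35 log units; beyond the scatter), the first change at this position that can be read as a single step. The step is modest, and compound 4 still gives a measured value without the amino group or the six-membered aromatic ring. No available data give a reason for this step.

As far as these compounds go, the nitrogen and the ring leave in one swap, so their separate contributions remain open. A plain aminomethyl group or a carboxylic acid at this place remains untested among the compounds shown.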